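Capping the free hydroxy of compound 3

The source may hold more compounds than are shown below. What is called first, only, known or untested is meant among the compounds shown, and "the series" means these compounds.

Three compounds have been measured so far in a functional assay on CNE2Z cells (Homo sapiens) for inhibition, read by MTT assay, with a stated time of 72 h (on this read-out higher numbers stand for weaker inhibition and lower numbers for stronger inhibition), with these results:

- compound 1 `C=CCc1ccc(O)c(-c2ccc(OCc3ccccc3)c(CC=C)c2)c1` gives 30300 nM in the assay
- compound 2 `C=CCc1ccc(OCc2ccc(Cl)cc2Cl)c(-c2ccc(O)c(CC=C)c2)c1` gives 24200 nM in the assay
- compound 3 `C=CCc1ccc(O)c(-c2ccc(OCc3ccc(Cl)c(Cl)c3)c(CC=C)c2)c1` gives 17800 nM in the assay

These three values lie within the usual scatter of one another, so compound 3 stands level with compound 1 and compound 2, and the set shows no ranking. The next compound is compound 4 `C=CCc1ccc(OCc2ccc(Cl)c(Cl)c2)c(-c2ccc(OCc3ccc(Cl)c(Cl)c3)c(CC=C)c2)c1` which differs from compound 3 at a single place (3,4-dichlorobenzyl in place of hydrogen on an oxygen on an aromatic ring). It carries 3,4-dichlorobenzyl in place of hydrogen on an oxygen on an aromatic ring, so a hydroxy becomes (3,4-dichlorobenzyl)oxy.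

For the measured compounds named here, only one measured step is available, a 1.7-fold lower number from compound 1 to compound 3 (0.23 log units; within the scatter) and it lies within the scatter. That step exchanges phenyl for 3,4-dichlorophenyl and leaves the hydroxy untouched, so it bears on this change only indirectly. Going by the values given here, all three measured compounds keep a free hydroxy, and the data hold no compound without one. The estimate is therefore anchored on compound 3 at 17800 nM with a wide range. In this assay the expected change is an estimated 1.4-fold higher number from compound 3 to compound 4 (0.15 log units; within the scatter) and no step beyond the scatter is expected. Compound 4 is estimated at 25000 nM and is expected to fall between 10000 nM and 65000 nM.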

Compound 4, half-maximal inhibitory concentration: > 50000 nM
Compound 4: only a limit was reported (the forecaster's own chance of this, stated with the estimate: 15%); at least 2.0-fold (0.30 log units) between middle value and limit.
By their numbers in this assay, from the lowest: compounds 3, 2 and 1 (each within the scatter of the next). At a limit, above all of these: compound 4.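

Capping the free hydroxy of compound 3 with 3,4-dichlorobenzyl moved the read-out beyond the scatter in this assay, giving an at least 2.8-fold higher number from compound 3 to compound 4 (0.44 log units; beyond the scatter); the earlier exchange on the benzyl ring, a 1.7-fold lower number from compound 1 to compound 3 (0.23 log units; within the scatter), had not. For the compounds shown here, compound 4 is the only one of the four compounds with no free hydroxy, and its entry of > 50000 nM is a limit, not a number. Going by these compounds alone, this oxygen on an aromatic ring therefore proved more sensitive to change than the earlier compounds could show, with weaker inhibition on capping, though the full size of the step remains unknown: the limit of > 50000 nM in this assay, at which 1 of the 4 values shown sits.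

The compounds shown do not separate the loss of the hydroxy hydrogen from the arrival of the large 3,4-dichlorobenzyl group, a question that a methyl or an acetyl on this oxygen would help to settle. They also leave open whether a chain ending in an amine or a carboxylic acid on this oxygen would restore inhibition to the level of compound 3.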